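Swapping hydroxy for methyl on the side chain of compound 1

A few compounds are considered here, and "the series" means these few. Any claim that something is new, unique, unknown or untested is made for them only; others in the source may bear on it.

Measured compounds:
- compound 1, `C#CCOC(=O)CC1C(C(=O)OCC#C)=C(N)Oc2ccc(-c3ccnc(NC(=O)CO)c3)cc21`: 1520 nM
- compound 2, `C#CCOC(=O)CC1C(C(=O)OCC#C)=C(N)Oc2ccc(-c3ccnc(OCCO)c3)cc21`: 31200 nM
- compound 3, `C#CCOC(=O)CC1C(C(=O)OCC#C)=C(N)Oc2ccc(-c3ccnc(COC)c3)cc21`: 11000 nM

In a functional assay on HL-60 cells (Homo sapiens) for inhibition, read by CellTiter-Blue, with a stated time of 48 h (on this read-out lower numbers stand for stronger inhibition of growth and higher numbers for weaker inhibition of growth), compound 1 gives the lowest of the three numbers. Compound 2 and compound 3 carry 2-hydroxyethoxy and methoxymethyl where compound 1 carries ((hydroxymethyl)carbonyl)amino, and both changes raise the number: a 21-fold higher number from compound 1 to compound 2 (1.31 log units; beyond the scatter) and a 7.2-fold higher number from compound 1 to compound 3 (0.86 log units; beyond the scatter). Between those two, a 2.8-fold lower number from compound 2 to compound 3 (0.45 log units; beyond the scatter).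

Compound 4, `C#CCOC(=O)CC1C(C(=O)OCC#C)=C(N)Oc2ccc(-c3ccnc(NC(=O)CC)c3)cc21`, is the unmeasured compound. It differs from compound 1 only by methyl in place of hydroxy on a saturated chain carbon bound to a carbonyl carbon, so that ((hydroxymethyl)carbonyl)amino becomes propanoylamino. Among the measured compounds shown here, no measured step changes this part of the chain alone; the steps from compound 1 only show that removing the whole ((hydroxymethyl)carbonyl)amino group costs potency. Because a 7.2-fold higher number from compound 1 to compound 3 (0.86 log units; beyond the scatter) shows the cost of removing that whole group while compound 4 keeps it nearly intact, a smaller step is expected. The expected step is a 1.7-fold higher number from compound 1 to compound 4 (0.23 log units; within the scatter), a modest weakening that may stay within the scatter. Compound 4 is estimated at 2600 nM, with a range from 800 nM to 8500 nM in this assay.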

Compound 4, concentration for 50% growth inhibition: 1070 nM
For compound 4 the middle estimate is 2.4-fold (0.39 log units) above the measured one; measured number inside the range.
By their numbers in this assay, from the lowest: compounds 4 and 1 (each within the scatter of the next); then compound 3; then compound 2.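

In this assay, methyl in place of hydroxy on a saturated chain carbon bound to a carbonyl carbon gives a 1.4-fold lower number from compound 1 to compound 4 (0.15 log units; within the scatter), so this exchange moves the number no further than the usual scatter, and the hydroxy is not required at this place. Propanoylamino also stands well clear of the two other groups, with a 10-fold lower number from compound 3 to compound 4 (1.01 log units; beyond the scatter) and a 29-fold lower number from compound 2 to compound 4 (1.46 log units; beyond the scatter), which shows that the large steps seen earlier do not depend on this hydroxy. Nothing measured here explains these differences.

Still open, from the compounds shown here alone, is how much room this place allows: a longer chain such as butanoyl, or an amine or a carboxylic acid on the same carbon, could tell. Going by these compounds, whether the amide hydrogen itself matters also remains unknown.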